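The source may hold more compounds than are shown below. What is called first, only, known or untested is meant among the compounds shown, and "the series" means these compounds.

Measured so far:
Compound 1 `Cc1cccc(C(=O)NCCC2CCN(S(=O)(=O)NC(=O)NC[C@@H]3C[C@@H]4C=C[C@@H]3C4)CC2)n1` gives 20% in a functional assay on the whole organism (blood) with Rattus norvegicus as the target, with stated times of 24 h and 1 h, at a dose of 5 mg/kg by the intraperitoneal route; a higher number here means a stronger effect of the compound at the dose given, a lower number a weaker effect.
Compound 2 `COc1ccc(C(=O)NCCC2CCN(S(=O)(=O)NC(=O)NC[C@@H]3C[C@@H]4C=C[C@@H]3C4)CC2)cn1` gives 11% in this assay.
Compound 3 `COc1ccncc1C(=O)NCCC1CCN(S(=O)(=O)NC(=O)NC[C@@H]2C[C@@H]3C=C[C@@H]2C3)CC1` gives 14% in this assay.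

Among these three numbers compound 3 holds the second highest place. Its nearest neighbour is compound 2, with a step of a number 3 percentage points higher from compound 2 to compound 3 (within the scatter), and its furthest is compound 1, with a step of a number 6 percentage points lower from compound 1 to compound 3 (within the scatter); both steps stay within the scatter, so the three compounds cannot be ranked against each other on this evidence.

Compound 4 `O=C(NC[C@@H]1C[C@@H]2C=C[C@@H]1C2)NS(=O)(=O)N1CCC(CCNC(=O)c2ccc3ccccc3n2)CC1` is the next compound to be measured. It differs from compound 3 in a single place: quinolin-2-yl in place of 4-methoxypyridin-3-yl on a carbonyl carbon. Every step measured so far also changes the group on this carbonyl carbon. Besides the two steps already named, the change from compound 1 to compound 2 gave a number 9 percentage points lower from compound 1 to compound 2 (within the scatter). All three such changes left the result within the scatter of repeated measurements. The quinolin-2-yl group is larger than any group tried so far, yet the earlier steps give no reason to expect a move beyond the scatter in this assay in either direction.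

Accordingly the step from compound 3 to compound 4 is expected to be a number 1 percentage points higher from compound 3 to compound 4 (within the scatter). Compound 4 is therefore estimated at 15%, within a range from 5% to 28%.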

Compound 4, a percentage reported as activity, at one dose (the size of the read-out at that dose, not a potency): 21%
The estimate for compound 4 lay 6 percentage points below the measured number; low and high end bracket the measured number.
By their numbers in this assay, from the lowest: compounds 2, 3, 1 and 4 (each within the scatter of the next).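

In this assay, quinolin-2-yl brings the largest group so far onto the carbonyl carbon, with 10 heavy atoms and two six-membered aromatic rings, yet all three new comparisons stay within the scatter (a number 7 percentage points higher from compound 3 to compound 4 (within the scatter); a number 10 percentage points higher from compound 2 to compound 4 (within the scatter); a number 1 percentage points higher from compound 1 to compound 4 (within the scatter)). The position therefore now has four different groups on it, including one with a second aromatic ring and no oxygen, and none of the new steps separates quinolin-2-yl from the single-ring groups. No measurement shown here bears on why the read-out responds in this way.

On these data alone, what remains open is whether any group on this carbonyl carbon can move the read-out beyond the scatter, for example a non-aromatic cyclohexyl group, a plain phenyl ring, or a quinoline carrying an amine or a carboxylic acid. Since each compound is shown at a single dose, the compounds also leave open whether potency differs among them, and whether a change elsewhere in the shared core, such as a longer chain before the amide nitrogen, would matter more than the group at this position.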